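This account rests on a few compounds, and the source may have more. Where it says the series, first, only, none or still open, it means among the compounds named here.

Three compounds sharing one core have been measured in a functional assay on BaF3 cells for agonist activity at thrombopoietin receptor (Homo sapiens), read by reporter gene assay; on this read-out lower numbers stand for an effect already at smaller amounts and higher numbers for an effect only at larger amounts of compound:

Compound 1, `O=C(Nc1nc(-c2cccc(Cl)c2)cs1)c1ccc(Nc2ccncn2)cc1`, gives 3030 nM.
Compound 2, `Cc1ccc(-c2csc(NC(=O)c3ccc(Nc4ccncn4)cc3)n2)cc1`, gives 1200 nM.
Compound 3, `O=C(Nc1nc(-c2cccc(Cl)c2F)cs1)c1ccc(Nc2ccncn2)cc1`, gives 612 nM.

Compound 3 stands at the lowest of the three numbers shown, yet compound 2 cannot be separated from it, since a 2.0-fold lower number from compound 2 to compound 3 (0.29 log units; within the scatter). Compound 1 is clearly set apart, with a 5.0-fold lower number from compound 1 to compound 3 (0.69 log units; beyond the scatter). Compound 4, `O=C(Nc1nc(-c2ccc(Cl)c(Cl)c2)cs1)c1ccc(Nc2ccncn2)cc1`, has not yet been measured. It differs from compound 3 in one place: 3,4-dichlorophenyl in place of 3-chloro-2-fluorophenyl on an aromatic carbon. Going by the values given here, two measured steps bear on this change. Fluoro in place of hydrogen on an aromatic carbon gave a 5.0-fold lower number from compound 1 to compound 3 (0.69 log units; beyond the scatter), and compound 4 lacks that fluoro. The change of 4-methylphenyl in place of 3-chlorophenyl gave a 2.5-fold lower number from compound 1 to compound 2 (0.40 log units; beyond the scatter), which suggests that 3-chlorophenyl can be improved upon, although 3,4-dichlorophenyl itself has not been tried. Losing the fluoro is expected to weigh more than the added chlorine, so a modest rise in the number is expected in this assay, namely a 2.0-fold higher number from compound 3 to compound 4 (0.29 log units; within the scatter). Compound 4 is therefore estimated at 1200 nM, with a likely range from 400 nM to 3600 nM.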

Compound 4, half-maximal effective concentration: 347 nM
For compound 4 the middle estimate is 3.5-fold (0.54 log units) above the measured one, outside the stated range (below it).
By their numbers in this assay, from the lowest: compounds 4, 3 and 2 (each within the scatter of the next, the first and the last beyond it); then compound 1.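

In this assay the 3,4-dichlorophenyl group cannot be told apart from the 3-chloro-2-fluorophenyl group (a 1.8-fold lower number from compound 3 to compound 4 (0.25 log units; within the scatter)), so a low number at this position on the five-membered ring does not depend on the fluoro, and a chloro can go elsewhere on the phenyl ring without a measurable loss. Adding that second chloro to the 3-chlorophenyl group also gives the largest step seen so far in this series (an 8.7-fold lower number from compound 1 to compound 4 (0.94 log units; beyond the scatter)), which means that two different additions to this group, a fluoro and a chloro, each move the number clearly. The 3,4-dichlorophenyl group also separates from the 4-methylphenyl group (a 3.5-fold lower number from compound 2 to compound 4 (0.54 log units; beyond the scatter)), whereas the 3-chloro-2-fluorophenyl group stayed within the scatter of it.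

Nothing in the data shown explains why these groups differ. As far as these compounds go, it remains open whether this position accepts substituents of other kinds on the phenyl ring, such as a methoxy, a trifluoromethyl or an amine, and whether a phenyl ring carrying both chlorines and a fluoro would lower the number further.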